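Notes on the step from compound 2 to compound 3

The source may report more compounds than this note shows. Statements on the series, on what has been measured and on what is new or still open speak of the compounds shown alone.

In a functional assay on HT-1080 cells (Homo sapiens) for cytotoxicity, read by MTT assay, with a stated time of 72 h (a lower number here means a stronger inhibitor, a higher number a weaker inhibitor), compound 1 `COc1cccc(/C=C2\CCC/C(=C\c3ccccc3Br)C2=O)c1OC` gives 10800 nM and compound 2 `COc1cccc(/C=C2\CCC/C(=C\c3cccc(OC)c3OC)C2=O)c1` gives 9900 nM on the shared core. Among the compounds with values here, these are the only two numbers so far, and compound 2 stands level with compound 1 within the scatter.

The next structure is compound 3 `COc1cccc(/C=C2\CCC/C(=C\c3ccc(Cl)cc3Cl)C2=O)c1OC` and the change is 2,4-dichlorophenyl in place of 3-methoxyphenyl on a double-bonded chain carbon bound to a double-bonded ring carbon with 2,4-dichlorophenyl in place of 3-methoxyphenyl on a double-bonded chain carbon bound to a double-bonded ring carbon. Within the data shown here, only one measured step bears on this place: a 1.1-fold lower number from compound 1 to compound 2 (0.04 log units; within the scatter) and it lies within the scatter. That step exchanged 2-bromophenyl for 3-methoxyphenyl at the same carbon. It is thin evidence, and no 2,4-dichlorophenyl example has been measured yet.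

On that single small step the expected change is a 1.2-fold lower number from compound 2 to compound 3 (0.09 log units; within the scatter) and no shift beyond the scatter is expected. In this assay the estimate for compound 3 is 8000 nM with an expected range of 3000 nM to 20000 nM for this one exchange.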

Compound 3, half-maximal inhibitory concentration: > 20000 nM
Compound 3 gave a limit, no number; the forecaster's own chance of this, stated with the estimate: 5%; at least 2.5-fold (0.39 log units) between middle value and limit.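

In this assay compound 3 is held at a limit of the assay and not at a number, the only such case in the series so far: the limit of > 20000 nM in this assay, at which 1 of the 3 values shown sits.

The exchange at the double-bonded chain carbon reads as an at least 2.0-fold higher number from compound 2 to compound 3 (0.30 log units; that floor lies within the scatter), and the exchange against the 2-bromophenyl group reads as an at least 1.8-fold higher number from compound 1 to compound 3 (0.26 log units; that floor lies within the scatter); both are floors, so the true size of each step is unknown and neither is shown to lie beyond the scatter. Within the data shown here, the earlier pair gave only a 1.1-fold lower number from compound 1 to compound 2 (0.04 log units; within the scatter), whereas 2,4-dichlorophenyl is the first group at this position whose value cannot be placed, so it may stand close to the other two groups or far from them.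

The compounds shown leave open whether the result belongs to the two chlorine atoms together or to one of them, a question that 2-chlorophenyl and 4-chlorophenyl at the same carbon would address. They also leave open how a group of a different kind at this carbon, such as an aminophenyl or a carboxylic acid on the phenyl ring, would read on the shared core.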